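The compounds below may be only part of what the source reports. "The series", "measured", "known", "first", "only" and "open" are said of these compounds alone.

Within the data shown here, in a functional assay on CNE-2 cells (Homo sapiens) for cytotoxicity, read by sulforhodamine B assay, with a stated time of 48 h (a lower number here means a stronger inhibitor, a higher number a weaker inhibitor), compound 3 (`COc1cc(/C=C/C(=O)c2ccc(N)c(-c3ccc(F)cc3)c2)ccc1O`) gives 5750 nM, the second highest of the three numbers measured so far. Compound 1 (`COc1cc(/C=C/C(=O)c2ccc(N)c(-c3ccc(F)cc3)c2)cc(Br)c1O`) stands higher at 25500 nM, and compound 2 (`COc1ccc(/C=C/C(=O)c2ccc(NC(C)=O)c(-c3ccc(F)cc3)c2)cc1OC`) stands lower at 2740 nM. The next compound, compound 4 (`COc1ccc(/C=C/C(=O)c2ccc(N)c(-c3ccc(F)cc3)c2)cc1OC`), departs from compound 3 by one change, methyl in place of hydrogen on an oxygen on an aromatic ring, or hydroxy to methoxy.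

Among the measured compounds shown here, no measured step covers that exchange. For the measured compounds named here, the only single-place step available is a 4.4-fold lower number from compound 1 to compound 3 (0.65 log units; beyond the scatter), a modest one with hydrogen in place of bromo on an aromatic carbon, so it shows that this part of the molecule can move the number but gives neither the size nor the direction for the new change. Compound 2 offers a weak hint, since it already carries the methoxy group and reads lower at 2740 nM, but it also has an acetamide where compound 3 has a free amine, so the two effects cannot be separated.

A small shift toward a lower number therefore seems the likeliest outcome, possibly no larger than the scatter. The expected step is a 1.4-fold lower number from compound 3 to compound 4 (0.16 log units; within the scatter). The estimated value for compound 4 is 4000 nM, with an expected range from 1500 nM to 11000 nM.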

Compound 4, half-maximal inhibitory concentration: 3510 nM
The estimate for compound 4 lay 1.1-fold (0.06 log units) above the measured number; low and high end bracket the measured number.
By their numbers in this assay, from the lowest: compounds 2, 4 and 3 (each within the scatter of the next, the first and the last beyond it); then compound 1.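

In this assay, among these compounds, hydroxy to methoxy gives a 1.6-fold lower number from compound 3 to compound 4 (0.21 log units; within the scatter), so methyl in place of hydrogen on this oxygen on an aromatic ring leaves the reading within the usual scatter, which the earlier compounds could not show. Compound 4 also isolates the second difference carried by compound 2: hydrogen in place of acetyl on a nitrogen on an aromatic ring gives a 1.3-fold higher number from compound 2 to compound 4 (0.11 log units; within the scatter), so that exchange too stays within the scatter, and the methoxy compounds with the free amine and the acetamide cannot be told apart in this assay. No supporting measurement is available to explain either result.

The compounds shown leave open whether a longer chain on this oxygen, such as ethoxy or benzyloxy, would shift the number beyond the scatter, or whether the oxygen can carry an acyl group such as acetyl with the same outcome. They also leave open whether the bromo effect seen in a 4.4-fold lower number from compound 1 to compound 3 (0.65 log units; beyond the scatter) would recur with a methoxy group in place of the hydroxy, or with chloro in place of bromo.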